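Swapping a carbamoylphenyl for a fluorophenyl on the oxazole core

A few compounds are considered here, and "the series" means these few. Any claim that something is new, unique, unknown or untested is made for them only; others in the source may bear on it.

In an assay (Rattus norvegicus) for inhibition of Fatty-acid amide hydrolase 1 (Homo sapiens) (a lower number here means a stronger inhibitor, a higher number a weaker inhibitor), compound 1 `Nc1cccc(-c2cnc(C(=O)CCCCCCc3ccccc3)o2)c1` gives 19 nM, and compound 2 `NC(=O)c1cccc(-c2cnc(C(=O)CCCCCCc3ccccc3)o2)c1` gives 6 nM, the lowest of the two numbers measured. Among the compounds with values here, the one known step, a 3.2-fold lower number from compound 1 to compound 2 (0.50 log units; beyond the scatter), runs from amino to carbamoyl. Compound 3 `O=C(CCCCCCc1ccccc1)c1ncc(-c2ccc(F)cc2)o1` differs from compound 2 by 4-fluorophenyl in place of 3-carbamoylphenyl on an aromatic carbon. That step removes the carbamoyl whose arrival in compound 2 gave the lower number, so a rise beyond the scatter is expected, estimated as a 7.5-fold higher number from compound 2 to compound 3 (0.88 log units; beyond the scatter). Compound 3 is therefore expected at 45 nM, within a range from 12 nM to 170 nM.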

Compound 3, inhibition constant: 62 nM
Estimate against measurement, compound 3: 1.4-fold (0.14 log units) below, and the stated range covers the measured number.
By their numbers in this assay, from the lowest: compound 2; then compound 1; then compound 3.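

In this assay, this position on the shared core is sensitive to what the phenyl ring carries: 4-fluorophenyl gives a 10-fold higher number from compound 2 to compound 3 (1.01 log units; beyond the scatter), and it also falls behind 3-aminophenyl, with a 3.3-fold higher number from compound 1 to compound 3 (0.51 log units; beyond the scatter). Of the three compounds, the two with a group at the 3 place of the phenyl ring give the lower numbers. No measurement on hand explains this order.

This swap changes both the group and its place on the phenyl ring, so the two effects cannot be separated. Plain phenyl, or a carboxylic acid in place of the carbamoyl, remains an open question.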